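Phenoxy for phenyl on a hydroxamic acid chain

A few compounds are considered here, and "the series" means these few. Any claim that something is new, unique, unknown or untested is made for them only; others in the source may bear on it.

Four hydroxamic acids share a core and differ in a side chain. In an ADME assay on Huh-7 cells (Homo sapiens) for cytotoxicity, read by MTT assay, with a stated time of 3 days (on this read-out higher numbers stand for lower toxicity in this test and lower numbers for higher toxicity in this test), compound 1 `O=C(/C=C/c1ccc(OCCc2ccccc2)cc1)NO` gives 16000 nM, and compound 2 `O=C(/C=C/c1cccc(OCCc2ccccc2)c1)NO` gives 12000 nM; how the two cores differ is not broken down here. Compound 3 `O=C(/C=C/c1ccc(OCCOc2ccccc2)cc1)NO` gives 5700 nM in this assay. Its change from compound 1 is phenoxy in place of phenyl on a saturated chain carbon, two bonds along the chain from an oxygen on an aromatic ring, and the step it made is a 2.8-fold lower number from compound 1 to compound 3 (0.45 log units; beyond the scatter). Compound 4 `O=C(/C=C/c1cccc(OCCOc2ccccc2)c1)NO` carries the same change from compound 2, (phenoxy in place of phenyl on a saturated chain carbon, two bonds along the chain from an oxygen on an aromatic ring), at an identical place. Because of a 2.8-fold lower number from compound 1 to compound 3 (0.45 log units; beyond the scatter), the expected step is a 2.8-fold lower number from compound 2 to compound 4 (0.45 log units; beyond the scatter). On that basis compound 4 is estimated at 4300 nM in this assay, with a likely range from 2000 nM to 9000 nM, resting on one earlier pair only.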

Compound 4, half-maximal cytotoxic concentration: 6000 nM
The estimate for compound 4 lay 1.4-fold (0.14 log units) below the measured number, and the stated range covers the measured number.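

On the core of compound 2, the change from phenyl to phenoxy in this assay gives a 2.0-fold lower number from compound 2 to compound 4 (0.30 log units; within the scatter), so this step on its own cannot be told apart from the scatter of repeated measurements. Set beside the same change on the core of compound 1, the two steps agree: the same change on two cores in this assay, a 2.8-fold lower number (0.45 log units; beyond the scatter) from compound 1 to compound 3 and a 2.0-fold lower number (0.30 log units; within the scatter) from compound 2 to compound 4, 1.4-fold (0.15 log units) apart, within the scatter of two such steps. This shows that the change read alike on these two cores, but two pairs do not show that it would carry to any other core, and they do not explain why the numbers behave this way.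

The compounds shown leave open whether an amine in place of the new oxygen would fit the same picture. They also leave open how a longer chain carrying the phenoxy would read.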